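The source may report more compounds than this note shows. Statements on the series, on what has been measured and on what is new or still open speak of the compounds shown alone.

Compound 1 `COc1ccc(/C=C2\Cc3cc(OC)c(OC)c(OC)c3C2=O)cc1O`: > 10000 nM
Compound 2 `COc1ccc(/C=C2\Cc3cc(OC)c(OC)c(OC)c3C2=O)cc1`: > 10000 nM

In a functional assay on A549 cells (Homo sapiens) for antiproliferative activity, read by MTT assay, with a stated time of 48 h (a higher number here means a weaker inhibitor of growth, a lower number a stronger inhibitor of growth), compound 2 gives > 10000 nM, which is a limit of the assay and not a number. Compound 1 gives > 10000 nM, also only a limit. Together they show (the limit of > 10000 nM in this assay, at which 2 of the 2 values shown sit).

Compound 3 `COc1ccc(/C=C2\Cc3cc(OC)c(OC)c(OC)c3C2=O)cc1N` has not yet been measured. Its change from compound 2 is amino in place of hydrogen on an aromatic carbon, ortho to a methoxy group.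

For the measured compounds named here, only one measured step bears on this, a step that the two limits leave unreadable from compound 1 to compound 2, and it has no readable size to carry over. Going by the values given here, no step of known size or direction can therefore be expected, and the most likely outcome is a result close to the same limit. The expected step is a number no higher from compound 2 to compound 3 (the limit leaves the size open). For compound 3 the estimated value is 10000 nM, with an expected range of 2000 nM to 30000 nM.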

Compound 3, concentration for 50% growth inhibition: > 10000 nM
Compound 3: a limit, no number (the forecaster's own chance of this, stated with the estimate: 70%); the middle value lies on the limit itself.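

In this assay compound 3, like compound 1 and compound 2, gives only a limit and not a number, so no step among these compounds can be read: the limit of > 10000 nM in this assay, at which 3 of the 3 values shown sit. The compounds shown leave open whether hydroxy, hydrogen or amino at this place changes growth inhibition at all.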